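Compound 1 and a 4-fluorobenzyl exchange

This account rests on a few compounds, and the source may have more. Where it says the series, first, only, none or still open, it means among the compounds named here.

In a functional assay on K562 cells (Homo sapiens) for inhibition, read by luminescence, with a stated time of 72 h, tested at 5 uM (a lower number here means less inhibition of growth, a higher number more inhibition of growth at the concentration tested), compound 1 (`C=CS(=O)(=O)NC/C=C/c1cc(OC)cc(O)c1C(=O)OC(C)C`) gives 36.2% as the lowest of three measured numbers. Compound 3 (`CCN(CC)C/C=C/C(=O)NC/C=C/c1cc(OCCc2ccc(F)cc2)cc(O)c1C(=O)OC(C)C`) stands higher with 49.8% and compound 2 (`COc1cc(O)c(C(=O)OCC(C)c2ccccc2)c(/C=C/CN2C(=O)C=CC2=O)c1`) stands furthest off with 74.9% in the same test. Both gaps to compound 1 lie beyond the scatter, but both of these compounds differ from it in more than one place. Compound 4 (`C=CS(=O)(=O)NC/C=C/c1cc(OC)cc(O)c1C(=O)OCc1ccc(F)cc1`) has not yet been measured. It keeps the core of compound 1 and differs from it in one place (4-fluorobenzyl in place of isopropyl on an oxygen next to a carbonyl group), with 4-fluorobenzyl in place of isopropyl on an oxygen next to a carbonyl group. Going by the values given here, no measured pair shows this change alone. Among the compounds with values here, the only guide is compound 2 with 74.9% in this assay and a six-membered aromatic ring in the group on that oxygen, although it also differs elsewhere. The expected size of the move is a number 13.8 percentage points higher from compound 1 to compound 4 (beyond the scatter) upward, an uncertain rise estimated to lie beyond the scatter. For compound 4 the estimated value is 50% with an expected range from 30% to 72% in this test.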

Compound 4, percent growth inhibition at one concentration: 52%
Compound 4: the middle estimate sits 2 percentage points below what was measured; the range from low to high includes it.
By their numbers in this assay, from the lowest: compound 1; then compounds 3 and 4 (each within the scatter of the next); then compound 2.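

The exchange of isopropyl for 4-fluorobenzyl on an oxygen next to a carbonyl group can now be read alone: in this assay it gives a number 15.8 percentage points higher from compound 1 to compound 4 (beyond the scatter), with the rest of compound 1 unchanged. Growth inhibition at the concentration tested is therefore not lost when this place carries the larger group with its six-membered aromatic ring, something compound 2 and compound 3 could not show, as each differs from compound 1 in more than one place. Nothing available explains the rise.

Whether the ring or the fluorine accounts for the step stays open, and a plain benzyl group or a longer chain such as 2-phenylethyl on the same oxygen would separate these. On these data alone, it is also open whether the same exchange would raise the number on compound 3, which keeps the isopropyl.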